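Shortening the carbonyl chain: compound 1 to compound 4

The compounds below may be only part of what the source reports. "The series", "measured", "known", "first", "only" and "open" are said of these compounds alone.

Going by the values given here, compound 1 `CCCC(=O)c1ccc(OCCCCOc2cc(C(=O)O)ccc2OC)c(C)c1O` gives 64.2% in an assay on HEK293 cells for positive allosteric modulation of metabotropic glutamate receptor 3 (Rattus norvegicus), read by thallium flux, with a stated time of 2.5 min (on this read-out lower numbers stand for smaller maximal responses and higher numbers for larger maximal responses), the highest of the three numbers measured so far. Compound 2 `Cc1c(OCCCCOc2ccc(C(=O)O)cc2Cl)ccc(C(=O)CC(C)C)c1O` gives 62.9%, within the scatter of compound 1. Compound 3 `Cc1ccc(C(=O)O)cc1OCCCCOc1ccc(C(=O)CC(C)C)c(O)c1C` gives 29.4%, the furthest from compound 1 and beyond the scatter. Among the compounds with values here, the one measured single-point step, a number 33.5 percentage points lower from compound 2 to compound 3 (beyond the scatter), concerns the carboxyphenyl end of the linker and not the chain on the carbonyl.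

Compound 4 `COc1ccc(C(=O)O)cc1OCCCCOc1ccc(C(C)=O)c(O)c1C` differs from compound 1 only by hydrogen in place of ethyl on a saturated chain carbon bound to a carbonyl carbon. Within the data shown here, no measured step touches this place. Compound 1 and compound 2 differ in more than one position, the carbonyl chain among them, and their values lie within the scatter of each other, which gives no sign that this part of the molecule drives the maximal response. A step of a number 6.2 percentage points lower from compound 1 to compound 4 (within the scatter) is therefore expected, that is, none beyond the scatter, with a wide range because the evidence is indirect. Compound 4 is estimated at 58%, between 40% and 76%.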

Compound 4, largest response reached (reported as percent of maximum), in percent of the reference or control that the assay uses: 34.8%
Beside the measured number, compound 4's estimate is 23.2 percentage points above it; the measured number lies below the stated range.
By their numbers in this assay, from the lowest: compounds 3 and 4 (each within the scatter of the next); then compounds 2 and 1 (each within the scatter of the next).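

In this assay, the chain on the carbonyl is the first place in the series shown where a single change moves the maximal response: hydrogen in place of ethyl on a saturated chain carbon bound to a carbonyl carbon gives a number 29.4 percentage points lower from compound 1 to compound 4 (beyond the scatter). The ethyl that leaves carries no ring, no hydrogen-bond donor or acceptor and no net charge, so the step is a change of chain alone, from propylcarbonyl to acetyl. Nothing measured on these compounds accounts for the step.

Open, as far as these compounds go, is whether an ethyl chain on the carbonyl would read with compound 1 or with compound 4, and whether a pentyl chain or a cyclopropyl group there would hold the response. Also open, from the compounds shown here alone, is whether the same shortening would act alike with the carboxyphenyl ends of compound 2 and compound 3.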